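Swapping the amide aryl group of a chalcone amide

The source may report more compounds than this note shows. Statements on the series, on what has been measured and on what is new or still open speak of the compounds shown alone.

A small set of chalcone-type compounds was examined in an ADME assay on SH-SY5Y cells (Homo sapiens) for cytotoxicity, read by MTT assay, with a stated time of 48 h; a lower number here means a stronger inhibitor, a higher number a weaker inhibitor. Compound 1, `COc1ccc(C(=O)/C=C/c2ccc(C(=O)Nc3cc([N+](=O)[O-])ccc3O)cc2)c(O)c1`, gives > 100000 nM there, which is a limit of the assay and not a number. Compound 2, `COc1ccc(C(=O)/C=C/c2cc(Br)c(OCc3ccccc3)c(OC)c2)c(O)c1`, likewise gives > 100000 nM in this assay, again a limit. Compound 3, `CCOCCOc1cccc(/C=C/C(=O)c2ccc(OC)cc2O)c1`, also returns > 100000 nM in this assay, a limit once more. Within the data shown here, all three values shown therefore sit at the limit of > 100000 nM in this assay, at which 3 of the 3 values shown sit, so compound 1 stands on the same footing as the others, and no measured step between compounds is available.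

The unmeasured compound 4, `COc1ccc(C(=O)/C=C/c2ccc(C(=O)Nc3ccc(C)cc3C)cc2)c(O)c1`, differs from compound 1 in one place: 2,4-dimethylphenyl in place of 2-hydroxy-5-nitrophenyl on an amide-type nitrogen. With every measured value resting at the limit, no basis is given for expecting a step in this assay beyond the scatter in either direction. The step from compound 1 to compound 4 is accordingly expected to be a number no higher from compound 1 to compound 4 (the limit leaves the size open). Compound 4 is estimated at 100000 nM in this assay, with a range from 40000 nM to 250000 nM, and it is expected most likely to be reported only as a limit.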

Compound 4, half-maximal inhibitory concentration: > 100000 nM
Compound 4: only a limit was reported; the forecaster's own chance of this, stated with the estimate: 80%; the middle value lies on the limit itself.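

Among these compounds, compound 1 and compound 4 are each reported only as a limit in this assay, so no step between them can be read: the limit of > 100000 nM in this assay, at which 4 of the 4 values shown sit.

The compounds shown leave open whether 2,4-dimethylphenyl in place of 2-hydroxy-5-nitrophenyl on an amide-type nitrogen changes the value at all.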